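A few compounds are considered here, and "the series" means these few. Any claim that something is new, unique, unknown or untested is made for them only; others in the source may bear on it.

Working notes on the series. In an ADME assay on BEAS-2B cells (Homo sapiens) for cytotoxicity, read by CCK-8 assay, with a stated time of 48 h (on this read-out higher numbers stand for weaker inhibition and lower numbers for stronger inhibition), compound 1 (`C=CC(=O)Nc1cccc(Oc2nc(Nc3ccc(N4CCN(C)CC4)c([N+](=O)[O-])c3)nc3c2ccn3COC(=O)C(C)(C)C)c1`) gives 5730 nM and compound 2 (`C=CC(=O)Nc1cccc(Oc2nc(Nc3ccc(N4CCN(C)CC4)c(OC)c3)nc3[nH]ccc23)c1`) gives 9890 nM. Going by the values given here, compound 2 therefore stands within the scatter of compound 1, the only other measured member, and the two numbers set no order between them.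

The next member is compound 3 (`C=CC(=O)Nc1cccc(Oc2nc(Nc3ccc(N4CCN(C)CC4)c([N+](=O)[O-])c3)nc3[nH]ccc23)c1`), which has not yet been measured. Relative to compound 2, it has nitro in place of methoxy on an aromatic carbon, ortho to a 4-methylpiperazin-1-yl group: nitro in place of methoxy on an aromatic carbon.

Among the compounds with values here, no pair of measured compounds differs in one place only, so the data hold no direct precedent for this change. Within the data shown here, the only guide is the narrow spread of the two numbers so far, with compound 1 at 5730 nM and compound 2 at 9890 nM. On that basis, no step beyond the scatter is expected in this assay, in either direction. The estimated change is a 1.3-fold lower number from compound 2 to compound 3 (0.12 log units; within the scatter), which is expected to remain within the scatter. For compound 3 the expected value is 7500 nM, with an estimated range of 3200 nM to 16000 nM.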

Compound 3, half-maximal inhibitory concentration: 3680 nM
Beside the measured number, compound 3's estimate is 2.0-fold (0.31 log units) above it; measured number inside the range.
By their numbers in this assay, from the lowest: compounds 3, 1 and 2 (each within the scatter of the next, the first and the last beyond it).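

In this assay, nitro in place of methoxy on an aromatic carbon, ortho to a 4-methylpiperazin-1-yl group, gives a 2.7-fold lower number from compound 2 to compound 3 (0.43 log units; beyond the scatter) as the first single-place change read at this position, so the number is not indifferent to what sits on this carbon, although the step is modest. Hydrogen in place of (((tert-butyl)carbonyl)oxy)methyl on an aromatic nitrogen, with nitro held on the carbon, gives a 1.6-fold lower number from compound 1 to compound 3 (0.19 log units; within the scatter) and so sets no order between the two compounds, leaving the change on the carbon as the only step beyond the scatter so far. No measurement at hand explains the step at the aromatic carbon.

On these data alone, only methoxy and nitro have been compared at this position, so one step gives no trend, and it remains open how a primary amine, a chlorine atom or a nitrile on the same carbon would place in this read-out. As far as these compounds go, it also remains open whether the (((tert-butyl)carbonyl)oxy)methyl group on the aromatic nitrogen would stay within the scatter when methoxy rather than nitro occupies the carbon.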